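The source may report more compounds than this note shows. Statements on the series, on what has been measured and on what is new or still open speak of the compounds shown alone.

In a functional assay on L02 cells (Homo sapiens) for inhibition, read by Griess assay, with stated times of 1 h and 24 h (on this read-out higher numbers stand for weaker inhibition and lower numbers for stronger inhibition), compound 1 `CNc1nc(/C=C/c2ccccc2)nc2ccsc12` gives > 1000000 nM as a limit and not a number. Going by these compounds, compound 3 `C(=C/c1ccco1)\c1nc(NC2CC2)c2sccc2n1` likewise shows > 1000000 nM as a limit, so its true value is unknown. Compound 2 `CN1CCN(c2nc(/C=C/c3ccccc3)nc3ccsc23)CC1` reads 198000 nM as a true number. Compound 4 `Fc1ccccc1CNc1nc(/C=C/c2ccco2)nc2ccsc12` differs from compound 3 by one change, 2-fluorobenzyl in place of cyclopropyl on a nitrogen on an aromatic ring with 2-fluorobenzyl in place of cyclopropyl on a nitrogen on an aromatic ring. Among the measured compounds shown here, the only measured guide is an at least 5.0-fold lower number from compound 1 to compound 2 (0.70 log units; beyond the scatter) after 4-methylpiperazin-1-yl replaced methylamino, a different swap in a related compound, so a lower number is expected with modest confidence. The expected change is an at least 3.3-fold lower number from compound 3 to compound 4 (0.52 log units; beyond the scatter) in this assay as an estimate. For compound 4 the estimated value is 300000 nM with an expected range from 60000 nM to 1000000 nM in this estimate.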

Compound 4, half-maximal inhibitory concentration: > 1000000 nM
Compound 4: a limit, no number (the forecaster's own chance of this, stated with the estimate: 40%); middle value at least 3.3-fold (0.52 log units) from the limit.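

No step from compound 3 to compound 4 can be read, because each result is a limit and not a number: the limit of > 1000000 nM in this assay, at which 3 of the 4 values shown sit.

Going by these compounds, whether 2-fluorobenzyl in place of cyclopropyl changes inhibition at all remains open.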